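The source may report more compounds than this note shows. Statements on the series, on what has been measured and on what is new or still open speak of the compounds shown alone.

In this study two hydroxamic acids have so far been measured in a functional assay on A2780cisR cells (Homo sapiens) for cytotoxicity, read by MTT assay, with a stated time of 72 h; on this read-out lower numbers stand for stronger inhibition and higher numbers for weaker inhibition. Compound 1 `CC(C)(C)NC(=O)C(C)(C)N(CCCCCC(=O)NO)C(=O)c1ccccc1` gives 579000 nM in this assay. Compound 2 `Cc1ccc(NC(=O)CN(CCCCCC(=O)NO)C(=O)c2cc(C)cc(C)c2)cc1` gives 2180 nM in this assay, the lower of the two numbers, and its gap to compound 1 lies beyond the usual scatter of repeated measurements. Compound 3 `Cc1cc(C)cc(C(=O)N(CCCCCC(=O)NO)CC(=O)NC2CCCCC2)c1` has not yet been measured. It differs from compound 2 in one place: cyclohexyl in place of 4-methylphenyl on an amide-type nitrogen. The cyclohexyl group enters on an amide-type nitrogen whose other neighbour is a carbonyl carbon. Among the compounds with values here, no pair of measured compounds differing in one place is available, so the size of such a step cannot be read from the data. The step of a 1.6-fold higher number from compound 2 to compound 3 (0.21 log units; within the scatter) is expected to be small, towards a somewhat higher number, and perhaps none beyond the scatter. Compound 3 is therefore estimated to give 3500 nM in this assay, within a range of 1000 nM to 12000 nM.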

Compound 3, half-maximal inhibitory concentration: 3810 nM
For compound 3 the middle estimate is 1.1-fold (0.04 log units) below the measured one; low and high end bracket the measured number.
By their numbers in this assay, from the lowest: compounds 2 and 3 (each within the scatter of the next); then compound 1.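

In this assay, within the data shown here, cyclohexyl in place of 4-methylphenyl on the amide-type nitrogen gives a 1.7-fold higher number from compound 2 to compound 3 (0.24 log units; within the scatter), the first step between measured compounds that differ in one place. At this position, then, a six-membered non-aromatic ring of carbon only and a methyl-bearing six-membered aromatic ring cannot be told apart in this read-out, although this rests on a single pair. No measured evidence is available to explain this result.

The compounds shown leave open whether the read-out would hold with a smaller group here, such as methyl, or with an amine or a carboxylic acid on the cyclohexyl ring. Compound 1 differs from compound 2 and compound 3 in more than one place, so no single change can be read from its much higher number.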